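The source may report more compounds than this note shows. Statements on the series, on what has been measured and on what is new or still open speak of the compounds shown alone.

Working notes on the series. Going by the values given here, in an in vivo ADME assay on the whole organism for pharmacokinetics, with Rattus norvegicus as the target (on this read-out higher numbers stand for fast clearance and lower numbers for slow clearance), compound 1 (`CCCS(=O)(=O)N1CCC(CNC(=O)c2ccccc2OC(F)(F)F)(C(=O)N2CCOCC2)CC1`) gives 18 mL/min/kg and compound 2 (`CCCS(=O)(=O)N1CCC(CNC(=O)c2c(F)cccc2F)(C(=O)N2CCOCC2)CC1`) gives 18 mL/min/kg so compound 2 stands level with compound 1, its only neighbour on these numbers. Compound 3 (`CCCS(=O)(=O)N1CCC(CNC(=O)c2ccccc2Cl)(C(=O)N2CCOCC2)CC1`) has not yet been measured. Its change from compound 2 is 2-chlorophenyl in place of 2,6-difluorophenyl on a carbonyl carbon. Among the compounds with values here, one measured step bears on this, an exchange at the same place on the same core: 2,6-difluorophenyl in place of 2-(trifluoromethoxy)phenyl (no change at the digits printed from compound 1 to compound 2 (within the scatter)). Within the data shown here, that is thin evidence, a single step, and no measured compound carries 2-chlorophenyl. On it, no shift beyond the scatter is expected in this assay in either direction. The expected step is small (a 1.1-fold higher number from compound 2 to compound 3 (0.05 log units; within the scatter)). The estimate for compound 3 is 20 mL/min/kg (expected range 11 mL/min/kg to 36 mL/min/kg).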

Compound 3, clearance: 18 mL/min/kg
Compound 3: middle estimate off by 1.1-fold (0.05 log units), on the high side; the measured number falls inside the stated range.
By their numbers in this assay, from the lowest: compounds 1, 2 and 3 (each within the scatter of the next).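

In this assay, the exchange at this carbonyl carbon now spans three groups rather than two: no change at the digits printed from compound 2 to compound 3 (within the scatter), and no change at the digits printed from compound 1 to compound 3 (within the scatter), the latter step being chloro in place of trifluoromethoxy on an aromatic carbon. The read-out therefore does not separate 2-(trifluoromethoxy)phenyl, 2,6-difluorophenyl and 2-chlorophenyl on the shared core, and none of the three compounds goes against this. The flat result also extends to a group with a single halogen and a smaller heavy-atom count than 2,6-difluorophenyl.

Still open, from the compounds shown here alone, is whether clearance stays level with an unsubstituted phenyl, or with a phenyl carrying an amine or a carboxylic acid, at this carbonyl carbon. No supporting data on these compounds bear on why the three groups read alike.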